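A few compounds are considered here, and "the series" means these few. Any claim that something is new, unique, unknown or untested is made for them only; others in the source may bear on it.

Measured compounds:
compound 1, `C=CCN1C(=O)C(=O)c2cc(-c3ccc(OC)cc3)ccc21`, 7090 nM
compound 2, `COc1ccc(-c2ccc3c(c2)C(=O)C(=O)N3Cc2ccc(Cl)c(Cl)c2)cc1`, 990 nM
compound 3, `COc1ccc(-c2ccc3c(c2)C(=O)C(=O)N3Cc2ccc(OC)c(OC)c2)cc1`, 1350 nM

In a functional assay on HepG2 cells (Homo sapiens) for antiproliferative activity, read by MTT assay, with a stated time of 48 h (a higher number here means a weaker inhibitor, a lower number a stronger inhibitor), compound 3 stands second highest of the three numbers; its nearest neighbour is compound 2, with a 1.4-fold higher number from compound 2 to compound 3 (0.13 log units; within the scatter), while the largest gap is a 5.3-fold lower number from compound 1 to compound 3 (0.72 log units; beyond the scatter). The step to compound 4, `COc1ccc(-c2ccc3c(c2)C(=O)C(=O)N3Cc2ccc3ccccc3c2)cc1`, is naphthalen-2-yl in place of 3,4-dimethoxyphenyl on a saturated chain carbon bound to an amide-type nitrogen in a ring.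

Within the data shown here, two measured steps bear on this change, both at the same place: a 7.2-fold lower number from compound 1 to compound 2 (0.86 log units; beyond the scatter) and a 5.3-fold lower number from compound 1 to compound 3 (0.72 log units; beyond the scatter) show that an aromatic group on this carbon lowers the number modestly relative to vinyl, whereas a 1.4-fold higher number from compound 2 to compound 3 (0.13 log units; within the scatter) shows that exchanging one substituted phenyl for another leaves the number within the scatter. Since naphthalen-2-yl is again an aromatic group at that position, compound 4 is expected to stay close to compound 3, with a 1.4-fold lower number from compound 3 to compound 4 (0.13 log units; within the scatter) not expected to exceed the scatter. Compound 4 is therefore estimated at 1000 nM, in the range 400 nM to 2500 nM.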

Compound 4, half-maximal inhibitory concentration: 380 nM
For compound 4 the middle estimate is 2.6-fold (0.42 log units) above the measured one, outside the stated range (below it).
By their numbers in this assay, from the lowest: compound 4; then compounds 2 and 3 (each within the scatter of the next); then compound 1.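

In this assay, compounds 2 and 3 alone suggested that the aromatic group at this place could be exchanged without consequence, but naphthalen-2-yl separates itself from both substituted phenyl groups, with a 3.6-fold lower number from compound 3 to compound 4 (0.55 log units; beyond the scatter) and a 2.6-fold lower number from compound 2 to compound 4 (0.42 log units; beyond the scatter) both beyond the scatter. The choice of aromatic group on this saturated chain carbon therefore does matter, and the distance from vinyl widens to a 19-fold lower number from compound 1 to compound 4 (1.27 log units; beyond the scatter) as the largest step in the set. No measurement shown here gives a reason for this difference.

Going by these compounds, whether an unsubstituted phenyl, naphthalen-1-yl or a quinolinyl group would lie near compound 4 or near compounds 2 and 3 remains open. On these data alone, all four compounds also carry the same 4-methoxyphenyl-bearing core, so it is unknown whether naphthalen-2-yl would give a similar step with a different group, such as an amine, on that core.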